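Swapping 4-fluorophenyl for pyridin-2-yl on a sulfonyl sulfur

A few compounds are considered here, and "the series" means these few. Any claim that something is new, unique, unknown or untested is made for them only; others in the source may bear on it.

Compound 1 `CCn1c([C@@H](C)NS(=O)(=O)c2ccc(Cl)cc2)nc2ccc(CO)cc21` gives 84 mL.min-1.g-1
Compound 2 `CCn1c(C(C)NS(=O)(=O)c2ccc(Cl)cc2)nc2cnccc21` gives 35 mL.min-1.g-1
Compound 3 `CCn1c([C@@H](C)NS(=O)(=O)c2ccc(F)cc2)nc2ccc(C(F)(F)F)cc21` gives 26 mL.min-1.g-1

All three were measured in an ADME assay (liver) for metabolic stability, with Liver microsome (Homo sapiens) as the target, read by LC-MS, using microsomes and NADPH, with a stated time of 5 min, at 37 degrees C (on this read-out lower numbers stand for slow clearance and higher numbers for fast clearance), and differ in more than one place. Compound 3 (26 mL.min-1.g-1) sits within the usual scatter of compound 2 (35 mL.min-1.g-1), and clearly under compound 1 (84 mL.min-1.g-1). Compound 4 `CCn1c([C@@H](C)NS(=O)(=O)c2ccccn2)nc2ccc(C(F)(F)F)cc21` alters compound 3 in one place: pyridin-2-yl in place of 4-fluorophenyl on a sulfonyl sulfur. Going by the values given here, no measured pair shows this swap directly, so only a small move towards slower clearance is expected. The expected change is a 1.3-fold lower number from compound 3 to compound 4 (0.11 log units; within the scatter) and it may not exceed the scatter. Compound 4 is estimated to give 20 mL.min-1.g-1 (range 9 mL.min-1.g-1 to 42 mL.min-1.g-1) in this assay once tested.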

Compound 4, intrinsic clearance in microsomes: < 3 mL.min-1.g-1
Compound 4 ended at the assay's limit; the forecaster's own chance of this, stated with the estimate: 10%; middle value at least 6.6-fold (0.82 log units) away from the limit.
By their numbers in this assay, from the lowest: compounds 3 and 2 (each within the scatter of the next); then compound 1. At a limit, below all of these: compound 4.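

In this assay, the group on the sulfonyl sulfur proves to matter: pyridin-2-yl in place of 4-fluorophenyl gives an at least 8.6-fold lower number from compound 3 to compound 4 (0.93 log units; beyond the scatter). Compound 1, compound 2 and compound 3 differ in more than one place, so none of them could isolate this change. The reading of compound 4 is a limit, not a number: the limit of < 3 mL.min-1.g-1 in this assay, at which 1 of the 4 values shown sits.

Still open, as far as these compounds go, is whether the ring nitrogen or the loss of fluorine carries this step, which a plain phenyl on the sulfonyl sulfur could separate. How a small chain such as methyl would read there is also unknown.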